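Sulfamoyl for carbamoyl at the aromatic position: expected cytotoxicity

The compounds below may be only part of what the source reports. "The series", "measured", "known", "first", "only" and "open" are said of these compounds alone.

Compound 1, `Cc1cc(/C=C/C#N)cc(C)c1Oc1cc(Nc2ccc(C#N)cc2)c(N)cc1CO`: 16300 nM
Compound 2, `Cc1cc(/C=C/C#N)cc(C)c1Oc1cc(Nc2ccc(C#N)cc2)c(N)cc1C(=O)O`: 14900 nM
Compound 3, `Cc1cc(/C=C/C#N)cc(C)c1Oc1cc(Nc2ccc(C#N)cc2)c(N)cc1C(N)=O`: > 23600 nM (a limit of the assay, not a number)

In an ADME assay on TZM cells (Homo sapiens) for cytotoxicity, read by XTT assay, with a stated time of 4 days (on this read-out lower numbers stand for higher toxicity in this test and higher numbers for lower toxicity in this test), compound 3 stands only at a limit, (the limit of > 23600 nM in this assay, at which 1 of the 3 values shown sits). The steps to it, an at least 1.4-fold higher number from compound 1 to compound 3 (0.16 log units; that floor lies within the scatter) and an at least 1.5-fold higher number from compound 2 to compound 3 (0.19 log units; that floor lies within the scatter), give floors within the scatter, as does a 1.1-fold lower number from compound 1 to compound 2 (0.04 log units; within the scatter). Compound 4, `Cc1cc(/C=C/C#N)cc(C)c1Oc1cc(Nc2ccc(C#N)cc2)c(N)cc1S(N)(=O)=O`, differs from compound 3 by sulfamoyl in place of carbamoyl on an aromatic carbon. Among the compounds with values here, no measured step exchanges carbamoyl for sulfamoyl; the three steps at this position all stay within the scatter, so no step beyond the scatter is expected in this assay, a step that the limit leaves unreadable from compound 3 to compound 4. Compound 4 is therefore estimated at 24000 nM, between 11000 nM and 55000 nM.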

Compound 4, half-maximal cytotoxic concentration: > 21800 nM
Compound 4 was reported as a limit; the forecaster's own chance of this, stated with the estimate: 55%; the middle value lies beyond the limit too.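

In this assay, compound 4, with sulfamoyl at this position, gives only a limit and not a number: the limit of > 21800 nM in this assay, at which 1 of the 4 values shown sits. The readable steps are an at least 1.4-fold higher number from compound 2 to compound 4 (0.16 log units; that floor lies within the scatter) and an at least 1.3-fold higher number from compound 1 to compound 4 (0.12 log units; that floor lies within the scatter), while the step between the two limits cannot be read. A sulfur-bearing group therefore joins the others at this position without any step printed beyond the scatter.

As far as these compounds go, how far the true values of compound 3 and compound 4 lie apart stays open. So does the reading of an aminomethyl or a methylsulfonyl group at this position.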